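The compounds below may be only part of what the source reports. "The series", "measured", "known", "first", "only" and "open" are said of these compounds alone.

Measured so far in an assay on HEK293 cells for displacement of a labelled ligand from Melanocortin receptor 4 (Homo sapiens); on this read-out lower numbers stand for stronger inhibition and higher numbers for weaker inhibition:
compound 1, `CC(C)C[C@H](N)c1cc(C(F)(F)F)ccc1N1CCN(C(=O)CSc2ccc(Cl)cc2Cl)CC1`: 1500 nM
compound 2, `CC(C)C[C@H](N)c1cc(C(F)(F)F)ccc1N1CCN(C(=O)COc2cccc(Cl)c2Cl)CC1`: 2500 nM

Compound 2 stands alongside compound 1 within the usual scatter: a 1.7-fold higher number from compound 1 to compound 2 (0.22 log units; within the scatter). Within the data shown here, with only two numbers, nothing in this set is separated from anything else beyond the scatter.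

The next compound is compound 3, `COc1cc(CC(C)C(=O)N2CCN(c3ccc(C(F)(F)F)cc3[C@@H](N)CC(C)C)CC2)ccc1Cl`, not yet measured in this assay. Relative to compound 2 the change is 1-(4-chloro-3-methoxybenzyl)ethyl in place of (2,3-dichlorophenoxy)methyl on a carbonyl carbon. Among the measured compounds shown here, the one measured step at this carbonyl carbon, a 1.7-fold higher number from compound 1 to compound 2 (0.22 log units; within the scatter), exchanged (2,4-dichlorophenyl)sulfanyl for 2,3-dichlorophenoxy and stayed within the scatter. For the measured compounds named here, the step to compound 3 goes further, replacing the (2,3-dichlorophenoxy)methyl with the 1-(4-chloro-3-methoxybenzyl)ethyl group, a change with no measured counterpart here. Going by the values given here, since the single comparable step, a 1.7-fold higher number from compound 1 to compound 2 (0.22 log units; within the scatter), moved little, the expectation for compound 3 is likewise no step beyond the scatter, with a wide range to reflect the untested nature of the new group.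

Compound 3 is estimated at 2000 nM, range 500 nM to 8000 nM, an expected step of a 1.3-fold lower number from compound 2 to compound 3 (0.10 log units; within the scatter).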

Compound 3, inhibition constant: 230 nM
The estimate for compound 3 lay 8.7-fold (0.94 log units) above the measured number; measured number outside the range, below it.
By their numbers in this assay, from the lowest: compound 3; then compounds 1 and 2 (each within the scatter of the next).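

In this assay, the group on the carbonyl carbon proves able to move the number beyond the scatter: 1-(4-chloro-3-methoxybenzyl)ethyl gives an 11-fold lower number from compound 2 to compound 3 (1.04 log units; beyond the scatter) against (2,3-dichlorophenoxy)methyl and a 6.5-fold lower number from compound 1 to compound 3 (0.81 log units; beyond the scatter) against ((2,4-dichlorophenyl)sulfanyl)methyl, so compound 3 stands apart from both earlier compounds, which remain within the scatter of each other. The change is a bundled one, with more heavy atoms entering than leaving, one chlorine for two, and the oxygen moved from the chain to a methoxy group on the ring, so this single comparison cannot assign the gain to any one of these features. No measurement in hand bears on why this group gives the lower number.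

As far as these compounds go, it remains open which part of the new group carries the step: a plain 1-(4-chlorobenzyl)ethyl group, a 4-chlorobenzyl group without the branching methyl, or a hydroxy or nitrile in place of the methoxy would each separate these parts. The configuration at the branched carbon, drawn undefined in compound 3, is also unresolved, so the two separate mirror-image forms at that carbon could still differ.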